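The source may report more compounds than this note shows. Statements on the series, on what has been measured and on what is new or still open speak of the compounds shown alone.

Measured so far:
Compound 1 `CNC(=O)c1cc(Oc2ccc(NC(=O)c3cc(-c4ccccc4)ncn3)cc2)ccn1`: 44200 nM
Compound 2 `CNC(=O)c1cc(Oc2ccc(NC(=O)c3cc(-c4ccc(C)cc4)ncn3)cc2F)ccn1`: 40200 nM

Both compounds were tested in a functional assay on PC-3 cells (Homo sapiens) for cytotoxicity, read by MTT assay, with a stated time of 72 h; a lower number here means a stronger inhibitor, a higher number a weaker inhibitor. For the measured compounds named here, in this test compound 2 gives 40200 nM, and this number lies within the usual scatter of the one for compound 1, so the two cannot be told apart.

The next compound to consider is compound 3 `CNC(=O)c1cc(Oc2ccc(NC(=O)c3cc(-c4ccccc4)ncn3)cc2F)ccn1`. It differs from compound 2 in a single place: hydrogen in place of methyl on an aromatic carbon. In words, hydrogen takes the place of methyl on an aromatic carbon, turning the 4-methylphenyl group into phenyl.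

Going by the values given here, no two measured compounds differ in only one place, so this change has no direct precedent in the data. Among the compounds with values here, the only guide is the pair of values already in hand, and they sit close together: compound 1 gives 44200 nM and compound 2 gives 40200 nM. On that thin basis, no change beyond the scatter is expected in this assay. The expected result is a 1.0-fold higher number from compound 2 to compound 3 (0.02 log units; within the scatter). For compound 3 the estimated value is 42000 nM, with an expected range of 22000 nM to 75000 nM.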

Compound 3, half-maximal inhibitory concentration: 44300 nM
Compound 3: the middle estimate sits 1.1-fold (0.02 log units) below what was measured; the range from low to high includes it.
By their numbers in this assay, from the lowest: compounds 2, 1 and 3 (each within the scatter of the next).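

In this assay, for the compounds shown here, putting hydrogen in place of methyl on an aromatic carbon, para to a large group, gives a 1.1-fold higher number from compound 2 to compound 3 (0.04 log units; within the scatter), so turning the 4-methylphenyl group into phenyl produces no readable difference, and this is the first direct look at that position. The second single-place comparison, fluoro in place of hydrogen on an aromatic carbon, gives a 1.0-fold higher number from compound 1 to compound 3 (0.00 log units; within the scatter), so this swap on the shared core cannot be told apart from the scatter of repeated measurements either. Nothing available offers an explanation for either result, and these two small swaps show only that methyl, fluoro and hydrogen cannot be separated in this test at the places tested.

From the compounds shown here alone, three compounds and two small swaps say little about how much this position can matter, so it remains open whether a larger or very different group in place of the methyl, such as an amine, a carboxylic acid or a longer chain like butyl, would move the number beyond the scatter. Going by these compounds, it also remains open whether chloro or methoxy on the aromatic carbon that carries the fluoro would behave any differently from fluoro and hydrogen.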